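From Compound 1 to Compound 4: One Side-Arm Exchanged

A few compounds are considered here, and "the series" means these few. Any claim that something is new, unique, unknown or untested is made for them only; others in the source may bear on it.

Of the compounds shown here, three sharing a common core have been measured in a functional assay on HCT-116 cells (Homo sapiens) for cytotoxicity, read by MTT assay, with a stated time of 72 h; a higher number here means a weaker inhibitor, a lower number a stronger inhibitor. Compound 1 `Cc1ccc(CNC(=S)Nc2ccc(C(=O)Nc3ccccc3N)cc2)cn1` gives 11000 nM. Compound 2 `Nc1ccccc1NC(=O)c1ccc(CNC(=O)c2cc3cccnc3[nH]2)cc1` gives 10000 nM, and compound 3 `Nc1ccccc1NC(=O)c1ccc(NC(=O)NCc2ccc(F)nc2)cc1` gives 14000 nM. Compound 1 stands second highest of the three, yet all three numbers lie within the scatter of one another, so no order among them can be claimed. Compound 4 `Nc1ccccc1NC(=O)c1ccc(NC(=S)NCc2ccccc2F)cc1` has not yet been measured and differs from compound 1 in a single place: 2-fluorophenyl in place of 6-methylpyridin-3-yl on a saturated chain carbon bound to an amide-type nitrogen. Among the compounds with values here, no measured pair shows a comparable change, so there is no basis for expecting a shift beyond the scatter in either direction. Compound 4 is therefore expected to give 10000 nM, between 4000 nM and 25000 nM. The expected step of a 1.1-fold lower number from compound 1 to compound 4 (0.04 log units; within the scatter) is essentially none.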

Compound 4, half-maximal inhibitory concentration: 6300 nM
Beside the measured number, compound 4's estimate is 1.6-fold (0.20 log units) above it; measured number inside the range.
By their numbers in this assay, from the lowest: compounds 4, 2, 1 and 3 (each within the scatter of the next, the first and the last beyond it).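

Within the data shown here, on a saturated chain carbon bound to an amide-type nitrogen, exchanging 6-methylpyridin-3-yl for 2-fluorophenyl gives a 1.7-fold lower number from compound 1 to compound 4 (0.24 log units; within the scatter) in this assay and is the first single-place step available here. It shows that a ring of carbon only, with no hydrogen-bond acceptor, can stand in this place without a change beyond the scatter. Nothing available explains this result. Going by these compounds, whether an amine or a carboxylic acid on this ring, or a longer chain carrying it, would move the number beyond the scatter remains open.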